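An amide swap expected to leave cytotoxicity unchanged

This account rests on a few compounds, and the source may have more. Where it says the series, first, only, none or still open, it means among the compounds named here.

Three amides sharing one core have been measured in a functional assay on SW1573 cells (Homo sapiens) for cytotoxicity, read by sulforhodamine B assay, with a stated time of 72 h; on this read-out lower numbers stand for stronger inhibition and higher numbers for weaker inhibition. Compound 1 `CC(=O)Nc1ccn([C@@H]2CO[C@H](CO)O2)c(=O)n1` carries an acetyl group and in this assay compound 1 gives 10700 nM. Compound 2 `CCCCC(=O)Nc1ccn([C@@H]2CO[C@H](CO)O2)c(=O)n1` gives 9130 nM, and compound 3 `O=C(Nc1ccn([C@@H]2CO[C@H](CO)O2)c(=O)n1)c1ccc(Br)cc1` gives 8870 nM. On these numbers compound 1 is not set apart from its companions: the step of a 1.2-fold lower number from compound 1 to compound 2 (0.07 log units; within the scatter) and the step of a 1.2-fold lower number from compound 1 to compound 3 (0.08 log units; within the scatter) both lie within the scatter, as does the step of a 1.0-fold lower number from compound 2 to compound 3 (0.01 log units; within the scatter).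

Compound 4 `COc1ccc(C(=O)Nc2ccn([C@@H]3CO[C@H](CO)O3)c(=O)n2)cc1` differs from compound 1 by 4-methoxyphenyl in place of methyl on a carbonyl carbon. The nearest guide is the step of a 1.2-fold lower number from compound 1 to compound 3 (0.08 log units; within the scatter), in which a 4-bromophenyl also replaced the methyl on the carbonyl carbon and nothing changed beyond the scatter; the step of a 1.0-fold lower number from compound 2 to compound 3 (0.01 log units; within the scatter) shows that a butyl and a 4-bromophenyl at that position likewise read alike. For the measured compounds named here, no measured compound carries a 4-methoxyphenyl, so the expectation rests on the pattern that three quite different groups on this carbonyl carbon returned numbers within the scatter of each other. The step of a 1.1-fold lower number from compound 1 to compound 4 (0.05 log units; within the scatter) is therefore expected to stay within the scatter. Compound 4 is estimated at 9500 nM in this assay, with a range from 4500 nM to 20000 nM.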

Compound 4, half-maximal inhibitory concentration: 10000 nM
Estimate against measurement, compound 4: 1.1-fold (0.02 log units) below; the range from low to high includes it.
By their numbers in this assay, from the lowest: compounds 3, 2, 4 and 1 (each within the scatter of the next).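

In this assay, the 4-methoxyphenyl group on the carbonyl carbon brings an oxygen and a hydrogen-bond acceptor that the groups in compounds 1, 2 and 3 lack at this place, yet the step of a 1.1-fold lower number from compound 1 to compound 4 (0.03 log units; within the scatter) stays within the scatter. The direct comparison of the two aryl amides, methoxy in place of bromo on an aromatic carbon, gives a 1.1-fold higher number from compound 3 to compound 4 (0.05 log units; within the scatter), so this exchange on the aromatic ring does not separate them, and the step of a 1.1-fold higher number from compound 2 to compound 4 (0.04 log units; within the scatter) likewise does not separate the aryl group from the butyl chain. Methyl, butyl, 4-bromophenyl and 4-methoxyphenyl on this carbonyl carbon therefore all read alike, with none of the four compounds going against that pattern, and no supporting data are available to say why.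

These compounds leave open whether a group carrying an amine or a carboxylic acid, or a chain much longer than butyl, would also read alike on this carbonyl carbon. They also leave open how a free amine in place of the amide would read on the shared core, since all four compounds keep the amide.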